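This account rests on a few compounds, and the source may have more. Where it says the series, first, only, none or still open, it means among the compounds named here.

Among the compounds with values here, compound 2 `CC(C)CSC(CCC/C=C(\c1ccccc1)c1cccnc1)C(=O)O` gives 110 nM in an assay (Equus caballus) for inhibition of Thromboxane-A synthase (Homo sapiens), using microsomes (a lower number here means a stronger inhibitor, a higher number a weaker inhibitor), the higher of the two numbers measured so far; compound 1 `COCC(CCC/C=C(\c1ccccc1)c1cccnc1)C(=O)O` gives 41 nM. Within the data shown here, the only measured step at this position, a 2.7-fold higher number from compound 1 to compound 2 (0.43 log units; beyond the scatter), shows that changing the group on this chain carbon moves the number modestly. Compound 3 `C=CCC(CCC/C=C(\c1ccccc1)c1cccnc1)C(=O)O` differs from compound 2 by allyl in place of isobutylsulfanyl on a saturated chain carbon bound to a carbonyl carbon and a saturated chain carbon. Among the measured compounds shown here, no measured step covers allyl itself, so the change is read as a move back toward the range of compound 1, of roughly the size of that earlier step. Compound 3 is therefore expected near 60 nM, within 25 nM to 150 nM. The estimated step is a 1.8-fold lower number from compound 2 to compound 3 (0.26 log units; within the scatter).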

Compound 3, half-maximal inhibitory concentration: 50 nM
Compound 3: middle estimate off by 1.2-fold (0.08 log units), on the high side; measured number inside the range.
By their numbers in this assay, from the lowest: compounds 1 and 3 (each within the scatter of the next); then compound 2.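

Replacing isobutylsulfanyl with allyl removes the sulfur and the chain branch together, and the number moves beyond the scatter (a 2.2-fold lower number from compound 2 to compound 3 (0.34 log units; beyond the scatter)). Against compound 1, the vinyl-for-methoxy change stays within the scatter (a 1.2-fold higher number from compound 1 to compound 3 (0.09 log units; within the scatter)), so this side chain needs neither oxygen nor sulfur to give a number in that range. No data here explain either shift.

Going by these compounds, whether the sulfur or the branched end drives the step from compound 2 stays open; an isobutyl group and a methylsulfanyl group would separate the two. On these data alone, an amine or a benzyl group on this carbon also remains open.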